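Isobutoxy to (4-methoxybenzyl)sulfanyl: expected shift in potency

A few compounds are considered here, and "the series" means these few. Any claim that something is new, unique, unknown or untested is made for them only; others in the source may bear on it.

Of the compounds shown here, three have been measured in an assay on CHO cells for antagonist activity at transient receptor potential cation channel subfamily V member 1 (Homo sapiens), read by FLIPR; on this read-out higher numbers stand for weaker inhibition and lower numbers for stronger inhibition. Compound 1 `CC(C(=O)NCc1ccc(C(F)(F)F)cc1N1CCC(Cc2ccc(F)cc2)CC1)c1ccc(NS(C)(=O)=O)c(F)c1` gives 0.4 nM. Compound 2 `CC(C)COc1cc(C(F)(F)F)ccc1CNC(=O)C(C)c1ccc(NS(C)(=O)=O)c(F)c1` gives 0.8 nM. Compound 3 `C[C@@H](C(=O)NCc1ccc(C(F)(F)F)cc1SC1CCCCC1)c1ccc(NS(C)(=O)=O)c(F)c1` gives 13.9 nM. On these numbers compound 2 stands second highest of the three: compound 1 is its nearest neighbour, a gap within the usual scatter, so the two are not ordered; compound 3 lies furthest from it, a gap beyond the scatter, so compound 3 is the weaker of that pair.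

Compound 4 `COc1ccc(CSc2cc(C(F)(F)F)ccc2CNC(=O)C(C)c2ccc(NS(C)(=O)=O)c(F)c2)cc1` is not yet measured. It differs from compound 2 in one place: (4-methoxybenzyl)sulfanyl in place of isobutoxy on an aromatic carbon. The entering group is larger than the leaving one and brings an aromatic ring, a larger departure from compound 2 than anything that has a measured counterpart here. Compound 1 shows that a large group at this position can sit with high potency, while compound 3 shows that another change there can cost it.

For compound 4 the step from compound 2 is estimated as a 6.3-fold higher number from compound 2 to compound 4 (0.80 log units; beyond the scatter), a loss, likely beyond the scatter. Compound 4 is expected to give 5 nM, with a range from 1 nM to 30 nM.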

Compound 4, inhibition constant: 2.3 nM
Compound 4: the middle estimate sits 2.2-fold (0.34 log units) above what was measured; the range from low to high includes it.
By their numbers in this assay, from the lowest: compounds 1 and 2 (each within the scatter of the next); then compound 4; then compound 3.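

In this assay, for the compounds shown here, (4-methoxybenzyl)sulfanyl in place of isobutoxy on this aromatic carbon gives a 2.9-fold higher number from compound 2 to compound 4 (0.46 log units; beyond the scatter) and so provides the first direct one-place reading at this position. The loss is modest, and compound 4 still reads 2.3 nM with a larger entering group that brings a six-membered aromatic ring of carbon only and a sulfur atom in place of the oxygen on the aromatic carbon. Nothing in hand accounts for the size of this step.

The change alters the linking atom, the chain and the terminal ring all at once, so the compounds shown do not assign the loss to any one of these. An isobutylsulfanyl or a (4-methoxybenzyl)oxy group at the same carbon would separate the linking atom from the rest of the substituent.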